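Compound 4: cyclopentyl replaces the branched alkyl of compound 3

A few compounds are considered here, and "the series" means these few. Any claim that something is new, unique, unknown or untested is made for them only; others in the source may bear on it.

Compound 3 `COc1cccc(-c2c(C)n(Cc3c(F)cccc3F)c(=O)n(C[C@@H](N)C(C)C)c2=O)c1F` gives 973 nM in an assay on HEK293 cells for binding affinity to Gonadotropin-releasing hormone receptor (Homo sapiens), read by radioligand binding (a higher number here means a weaker inhibitor, a lower number a stronger inhibitor), the highest of the three numbers measured. Compound 1 `COc1cccc(-c2c(C)n(Cc3c(F)cccc3F)c(=O)n(C[C@H](C)NCc3ccccc3)c2=O)c1F` gives 51 nM and compound 2 `COc1cccc(-c2c(C)n(Cc3c(F)cccc3F)c(=O)n(C[C@H](N)CC(C)C)c2=O)c1F` gives 6.4 nM in this assay. The steps of a 19-fold higher number from compound 1 to compound 3 (1.28 log units; beyond the scatter) and a 150-fold higher number from compound 2 to compound 3 (2.18 log units; beyond the scatter) are both large, so compound 3 is the weakest of the three. Compound 4 `COc1cccc(-c2c(C)n(Cc3c(F)cccc3F)c(=O)n(C[C@H](N)C3CCCC3)c2=O)c1F` carries amino(cyclopentyl)methyl in place of 1-amino-2-methylpropyl on a saturated chain carbon bound to an aromatic nitrogen. Within the data shown here, no measured step changes this carbon in the same manner; the two steps that reach compound 3 only show that 1-amino-2-methylpropyl sits far above both alternatives, so a move back towards them is plausible but its size is uncertain. A modest decrease, a 3.2-fold lower number from compound 3 to compound 4 (0.51 log units; beyond the scatter), is expected. Compound 4 is therefore estimated at 300 nM, within 60 nM to 1500 nM.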

Compound 4, inhibition constant: 10 nM
Beside the measured number, compound 4's estimate is 30-fold (1.48 log units) above it, and the stated range ends above it.
By their numbers in this assay, from the lowest: compounds 2 and 4 (each within the scatter of the next); then compound 1; then compound 3.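

In this assay the amino(cyclopentyl)methyl group gives a 97-fold lower number from compound 3 to compound 4 (1.99 log units; beyond the scatter) and a 5.1-fold lower number from compound 1 to compound 4 (0.71 log units; beyond the scatter) while a 1.6-fold higher number from compound 2 to compound 4 (0.19 log units; within the scatter) leaves cyclopentyl level with isobutyl, so a ring on this carbon is compatible with a low number. Compound 3 carries the opposite drawn arrangement at its stereocentre from compound 2 and compound 4, so the step to compound 4 joins that change to the ring. No evidence here accounts for these differences.
Open, as far as these compounds go, is how much of that step belongs to the stereocentre alone, and how cyclobutyl or cyclohexyl would read at this carbon.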